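A few compounds are considered here, and "the series" means these few. Any claim that something is new, unique, unknown or untested is made for them only; others in the source may bear on it.

In an ADME assay on L6 cells (Rattus norvegicus) for cytotoxicity, with a stated time of 72 h (on this read-out lower numbers stand for stronger inhibition and higher numbers for weaker inhibition), compound 1 `CN(C)C12CC(OC(=O)CN3CCCC3)C(C(c3ccccc3)C1)C(c1ccccc1)C2` gives 32700 nM and compound 2 `OC1CC2(N3CCCC3)CC(c3ccccc3)C1C(c1ccccc1)C2` gives 26800 nM. Going by the values given here, these are the only two numbers available, and they lie within the usual scatter of each other, so compound 2 stands level with compound 1 on this read-out. Both values sit in the same high range of concentrations. Compound 3 `O=C(CN1CCCC1)OC1CC2(N3CCCC3)CC(c3ccccc3)C1C(c1ccccc1)C2` has not yet been measured in this assay. It comes from compound 2 by placing ((pyrrolidin-1-yl)methyl)carbonyl in place of hydrogen on an oxygen on a saturated carbon. Among the compounds with values here, no step between measured compounds is available to size this change directly. However, compound 1 also carries ((pyrrolidin-1-yl)methyl)carbonyl on an oxygen on a saturated carbon, and its 32700 nM matches the value of compound 2 within the scatter. On that basis, no shift beyond the scatter is expected in this assay. The expected change is a 1.1-fold lower number from compound 2 to compound 3 (0.05 log units; within the scatter), a small step at most. For compound 3 the estimated value is 24000 nM, with an expected range from 9000 nM to 60000 nM.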

Compound 3, half-maximal inhibitory concentration: 42900 nM
The estimate for compound 3 lay 1.8-fold (0.25 log units) below the measured number; measured number inside the range.
By their numbers in this assay, from the lowest: compounds 2, 1 and 3 (each within the scatter of the next).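

In this assay, the hydroxy group of compound 2 can now be set directly against (((pyrrolidin-1-yl)methyl)carbonyl)oxy on the same saturated ring carbon, and this change gives a step that stays within the scatter (a 1.6-fold higher number from compound 2 to compound 3 (0.20 log units; within the scatter)). A second single change can also be read, pyrrolidin-1-yl in place of dimethylamino on a saturated ring carbon with the ((pyrrolidin-1-yl)methyl)carbonyl on the oxygen held fixed, and this step also stays within the scatter (a 1.3-fold higher number from compound 1 to compound 3 (0.12 log units; within the scatter)). No measured evidence bears on these results.

The compounds shown leave open how this assay would respond to other groups on this oxygen, such as acetyl, a longer chain ending in piperidine, or a chain carrying a carboxylic acid. They also leave open how it would respond to other amines on the saturated ring carbon, such as morpholine or piperazine, and whether any such group would give a step beyond the scatter.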